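A longer ester-linked selenocyanate chain in place of the amide

This account rests on a few compounds, and the source may have more. Where it says the series, first, only, none or still open, it means among the compounds named here.

Compound 1 `COc1ccc(N(C)c2nc(C)nc3ccccc23)cc1OCCN`: 343 nM
Compound 2 `COc1ccc(N(C)c2nc(C)nc3ccccc23)cc1C(=O)NCC[Se]C#N`: 1170 nM
Compound 3 `COc1ccc(N(C)c2nc(C)nc3ccccc23)cc1C[Se]C#N`: 316 nM

All three share one core and were tested in a functional assay on RKO cells (Homo sapiens) for inhibition, read by MTT assay, with a stated time of 48 h; on this read-out lower numbers stand for stronger inhibition and higher numbers for weaker inhibition. Compound 2 stands highest of the three numbers: the steps of a 3.4-fold higher number from compound 1 to compound 2 (0.53 log units; beyond the scatter) and a 3.7-fold lower number from compound 2 to compound 3 (0.57 log units; beyond the scatter) both lie beyond the scatter, while compound 1 and compound 3 sit within the scatter of each other.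

Compound 4 `COc1ccc(N(C)c2nc(C)nc3ccccc23)cc1C(=O)OCCCCCC[Se]C#N` differs from compound 2 by a group of 10 heavy atoms (7 carbon, 1 nitrogen, 1 oxygen, 1 selenium; no ring) in place of a group of 6 heavy atoms (3 carbon, 2 nitrogen, 1 selenium; no ring), on a carbonyl carbon. Within the data shown here, no measured step changes a group on the carbonyl carbon; the two steps that touch compound 2 each swap the whole group on the aromatic carbon and show only that other groups there gave lower numbers. The expectation for compound 4 is therefore uncertain: a number near that of compound 2, perhaps somewhat lower, a 1.5-fold lower number from compound 2 to compound 4 (0.17 log units; within the scatter). Compound 4 is estimated at 800 nM, between 250 nM and 2500 nM.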

Compound 4, half-maximal inhibitory concentration: 1990 nM
Compound 4: middle estimate off by 2.5-fold (0.40 log units), on the low side; the measured number falls inside the stated range.
By their numbers in this assay, from the lowest: compounds 3 and 1 (each within the scatter of the next); then compounds 2 and 4 (each within the scatter of the next).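

In this assay, the step on the carbonyl carbon is a 1.7-fold higher number from compound 2 to compound 4 (0.23 log units; within the scatter). Among these compounds, this is the first change made at this carbonyl carbon, and it shows that the amide-linked group can give way to a group of 10 heavy atoms, with 0 hydrogen-bond donors in place of 1, without a difference beyond the scatter. No available evidence explains this result.

From the compounds shown here alone, the step changes the linking atom and the chain length together, so their separate contributions stay unknown. An ester with a shorter chain, or an amide with the longer chain, would separate them.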